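Working notes: from nitro to 2-bromoethoxy

The compounds below may be only part of what the source reports. "The series", "measured", "known", "first", "only" and "open" are said of these compounds alone.

Values in a functional assay on A549 cells (Homo sapiens) for antiproliferative activity, read by MTT assay, with a stated time of 48 h (on this read-out higher numbers stand for weaker inhibition and lower numbers for stronger inhibition), for the compounds measured so far
- compound 1 `COc1ccc(N(C)c2ccnc(Cl)n2)cc1` gives 611 nM
- compound 2 `COc1ccc(N(C)c2ccnc(Cl)n2)cc1[N+](=O)[O-]` gives 3780 nM

Among the compounds with values here, compound 2 holds the higher of the two numbers, so it is the weaker of the pair, with compound 1 as its only neighbour. The next structure is compound 3 `COc1ccc(N(C)c2ccnc(Cl)n2)cc1OCCBr`, with 2-bromoethoxy in place of nitro on an aromatic carbon. Within the data shown here, only one measured step bears on this change. It is modest but beyond the scatter, and it puts nitro in place of hydrogen on the same aromatic carbon (a 6.2-fold higher number from compound 1 to compound 2 (0.79 log units; beyond the scatter)). Among the measured compounds shown here, no compound measured so far carries 2-bromoethoxy, so that step shows only that this carbon can move the number. With nitro gone, a partial return towards compound 1 at 611 nM is expected, though the size remains uncertain. The expected change in this assay is towards a lower number, estimated as a 2.5-fold lower number from compound 2 to compound 3 (0.40 log units; beyond the scatter) and smaller than the nitro step. The estimate for compound 3 is 1500 nM (expected range 400 nM to 5000 nM).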

Compound 3, half-maximal inhibitory concentration: 4640 nM
For compound 3 the middle estimate is 3.1-fold (0.49 log units) below the measured one, and the stated range covers the measured number.
By their numbers in this assay, from the lowest: compound 1; then compounds 2 and 3 (each within the scatter of the next).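

In this assay, exchanging nitro for 2-bromoethoxy on the aromatic carbon ortho to a methoxy group gives a 1.2-fold higher number from compound 2 to compound 3 (0.09 log units; within the scatter) and so does not separate the two groups, although they have no more in common than the atoms counted for each: nitro has 3 heavy atoms including nitrogen, and 2-bromoethoxy has 4 including bromine. Measured against hydrogen at the same carbon, 2-bromoethoxy gives a 7.6-fold higher number from compound 1 to compound 3 (0.88 log units; beyond the scatter) and nitro gives a 6.2-fold higher number from compound 1 to compound 2 (0.79 log units; beyond the scatter), so among the three compounds both substituents stand beyond the scatter from hydrogen, which now rests on two different groups rather than on nitro alone. No supporting data bear on why these two groups read alike at this position.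

The compounds shown leave open whether any group at this carbon would give the same reading as nitro and 2-bromoethoxy, or whether a small group such as fluorine, a hydroxyl or an amine would stay closer to compound 1 at 611 nM. They also leave open which part of 2-bromoethoxy carries the reading, which a plain ethoxy group, a longer bromoalkoxy chain or a terminal amine in place of bromine would test.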